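Swapping chloro for methyl on the benzyl sulfide

The source may report more compounds than this note shows. Statements on the series, on what has been measured and on what is new or still open speak of the compounds shown alone.

Of the compounds shown here, three sharing one core have been measured in an assay on CHO-K1 cells for antagonist activity at transient receptor potential cation channel subfamily V member 1 (Homo sapiens), read by FLIPR; a higher number here means a weaker inhibitor, a lower number a stronger inhibitor. Compound 1 `CC(C(=O)NCc1ccc(C(F)(F)F)nc1SCCOc1ccccc1)c1ccc(NS(C)(=O)=O)c(F)c1` gives 118 nM; compound 2 `COC(=O)CCSc1nc(C(F)(F)F)ccc1CNC(=O)C(C)c1ccc(NS(C)(=O)=O)c(F)c1` gives 1100 nM; compound 3 `CC(C(=O)NCc1ccc(C(F)(F)F)nc1SCc1ccc(Cl)cc1)c1ccc(NS(C)(=O)=O)c(F)c1` gives 674 nM. Compound 3 thus holds the second highest of the three numbers: the step of a 1.6-fold lower number from compound 2 to compound 3 (0.21 log units; within the scatter) lies within the scatter, while the step of a 5.7-fold higher number from compound 1 to compound 3 (0.76 log units; beyond the scatter) lies beyond it. The remaining step, a 9.3-fold higher number from compound 1 to compound 2 (0.97 log units; beyond the scatter), is also modest.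

Compound 4 `Cc1ccc(CSc2nc(C(F)(F)F)ccc2CNC(=O)C(C)c2ccc(NS(C)(=O)=O)c(F)c2)cc1` differs from compound 3 in one place: methyl in place of chloro on an aromatic carbon. Going by the values given here, none of the measured steps touches this ring; all three exchange the whole group bound to the sulfur, and even those larger exchanges moved this assay by no more than the modest 9.3-fold higher number from compound 1 to compound 2 (0.97 log units; beyond the scatter). Among the compounds with values here, an exchange of one heavy atom on an aromatic carbon of the 4-chlorobenzyl group therefore has no measured step to lean on, and with nothing in the data pointing one way or the other, the step is expected to stay within the scatter.

Compound 4 is expected to give about 600 nM in this assay, within 250 nM to 1500 nM, which would mean an estimated step of a 1.1-fold lower number from compound 3 to compound 4 (0.05 log units; within the scatter).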

Compound 4, half-maximal inhibitory concentration: 764 nM
The estimate for compound 4 lay 1.3-fold (0.10 log units) below the measured number, within the range that was stated.
By their numbers in this assay, from the lowest: compound 1; then compounds 3, 4 and 2 (each within the scatter of the next).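

In this assay the first exchange made on this ring itself gives a 1.1-fold higher number from compound 3 to compound 4 (0.05 log units; within the scatter) and so, at this aromatic carbon para to a large group, chloro and methyl cannot be told apart. With the methyl the benzyl sulfide also keeps the standing it had with the chloro: a 1.4-fold lower number from compound 2 to compound 4 (0.16 log units; within the scatter) stays within the scatter, while a 6.5-fold higher number from compound 1 to compound 4 (0.81 log units; beyond the scatter) remains beyond it, much like a 5.7-fold higher number from compound 1 to compound 3 (0.76 log units; beyond the scatter) and with the phenoxyethyl group still on the low side. Nothing measured here accounts for the two groups reading alike.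

The compounds shown leave open whether this carbon accepts other groups as readily, such as a methoxy group, an amine or a carboxylic acid, as only chloro and methyl have been compared there. They also leave open whether methyl and chloro would read alike at another carbon of this ring, or on the phenoxy ring of compound 1, which holds the lowest number of the four.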